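From Methyl to (Pyridin-4-yl)methyl on the Shared Core

The source may report more compounds than this note shows. Statements on the series, on what has been measured and on what is new or still open speak of the compounds shown alone.

Among the three compounds measured so far, compound 1 `CCCCNc1nc(N)nc2c1CN(C)CC2` stands lowest. In an assay on HEK293 cells for agonist activity at Toll-like receptor 8 (Homo sapiens), read by a luciferase reporter, with a stated time of 6 h (a lower number here means that less compound is needed, a higher number that more compound is needed for the effect), compound 1 gives 0.03 uM. The nearest of the others is compound 3 `CCCCNc1nc(N)nc2c1CN(Cc1ccc(OC(F)(F)F)cc1)CC2`, which in this assay gives 0.24 uM, a higher number, beyond the usual scatter. Furthest is compound 2 `CCCCNc1nc(N)nc2c1CCN(C(C)=O)C2`, which in this assay gives 0.4 uM, higher still and also beyond the scatter. No two of these compounds differ in one place only, so the three values stand side by side without a counted step between them.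

The account now turns to compound 4 `CCCCNc1nc(N)nc2c1CN(Cc1ccncc1)CC2`, which has not been measured. Its difference from compound 1 is counted as pyridin-4-yl in place of hydrogen on a saturated chain carbon bound to an amine nitrogen in a ring. Cut one bond further out, the change reads as methyl to (pyridin-4-yl)methyl.

Within the data shown here, compound 1 is the only compound with a methyl at that place, and both other compounds, which carry larger groups elsewhere on the core, give higher numbers. On that basis compound 4 is expected to show a step of a 5.0-fold higher number from compound 1 to compound 4 (0.70 log units; beyond the scatter) upward in the minimum effective concentration, beyond the scatter. The estimate for compound 4 in this assay is 0.15 uM, with a range from 0.04 uM to 0.6 uM.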

Compound 4, minimum effective concentration: 0.29 uM
The estimate for compound 4 lay 1.9-fold (0.29 log units) below the measured number; the measured number falls inside the stated range.
By their numbers in this assay, from the lowest: compound 1; then compounds 3, 4 and 2 (each within the scatter of the next).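

In this assay, the change from methyl to (pyridin-4-yl)methyl is a 9.7-fold higher number from compound 1 to compound 4 (0.99 log units; beyond the scatter), beyond the scatter. Among these compounds, this is the first step that can be counted here, so the low number of compound 1 can now be set against a change at one place alone, with the rest of the shared core held the same. Among the compounds shown here, it shows that, in this pair, putting pyridin-4-yl in place of hydrogen on the saturated chain carbon bound to an amine nitrogen in a ring comes with more compound being needed for the effect, although this single step gives only one entering group at that place. Nothing among the data shown explains why the number rises.

The compounds shown leave open whether the higher number goes with the aromatic ring itself, with its ring nitrogen or with the mere presence of a larger group at this place. A plain phenyl, a pyridin-2-yl or a short alkyl chain such as ethyl in the same place would be needed to separate these readings.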